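Ethyl to Methyl on a Chain Nitrogen: What to Expect

The source may report more compounds than this note shows. Statements on the series, on what has been measured and on what is new or still open speak of the compounds shown alone.

Compound 1, `Nc1ccccc1NC(=O)c1ccc(CSC(=S)N2CCN(c3ccc(Cl)cc3)CC2)cc1`, gives 17.2% in a functional assay on MGC-803 cells (Homo sapiens) for antiproliferative activity, read by CCK-8 assay, with a stated time of 72 h, tested at 8 uM; a lower number here means a weaker effect, a higher number a stronger effect of the compound at the concentration tested.
Compound 2, `CCN(Cc1ccncc1)C(=S)SCc1ccc(C(=O)Nc2ccccc2N)cc1`, gives 85.2% in this assay.
Compound 3, `COc1ccc(N2CCN(C(=S)SCc3ccc(C(=O)Nc4ccccc4N)cc3)CC2)cc1`, gives 22.9% in this assay.

Compound 2 stands highest of these three numbers. Its nearest neighbour is compound 3, which lies lower by a gap beyond the scatter, and compound 1 lies further below, also beyond the scatter. Going by the values given here, the only step between two measured compounds that differ in one place is a number 5.7 percentage points higher from compound 1 to compound 3 (within the scatter), and it concerns a substituent on an aromatic carbon at the far end of the shared core, a different place from the one changed here.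

Compound 4, `CN(Cc1ccncc1)C(=S)SCc1ccc(C(=O)Nc2ccccc2N)cc1`, differs from compound 2 by hydrogen in place of methyl on a saturated chain carbon bound to an amide-type nitrogen. Among the compounds with values here, no measured step touches this chain nitrogen, so the ethyl-to-methyl change has no direct precedent in the data; the one step that does exist was within the scatter. On that basis no step beyond the scatter is expected in this assay, and the estimate rests mainly on the value of compound 2.

Compound 4 is therefore expected to give about 80%, with a range from 60% to 93%. The expected step of a number 5.2 percentage points lower from compound 2 to compound 4 (within the scatter) is small.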

Compound 4, a percentage reported as inhibition, at one concentration (the size of the read-out at that concentration, not a potency): 83.2%
For compound 4 the middle estimate is 3.2 percentage points below the measured one; low and high end bracket the measured number.
By their numbers in this assay, from the lowest: compounds 1 and 3 (each within the scatter of the next); then compounds 4 and 2 (each within the scatter of the next).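

In this assay, going by these compounds alone, replacing ethyl with methyl on the chain nitrogen gives a number 2 percentage points lower from compound 2 to compound 4 (within the scatter), the first measured step at this position. Taking away this one carbon therefore leaves the read-out within the scatter, so at least between these two groups, the position shows no sensitivity to chain length. No measurement among the data bears on why this is so.

How far this tolerance extends remains open, since a longer chain such as butyl, or a carboxylic acid carried on the chain, appears at this nitrogen in none of the compounds shown. The read-out also gives only the size of the effect at one concentration, so it does not show whether two compounds this close would also give a similar effect at other concentrations.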